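A Longer Chain on Compound 1

The source may hold more compounds than are shown below. What is called first, only, known or untested is meant among the compounds shown, and "the series" means these compounds.

- Compound 1 `CCCC(=O)Nc1nc(N)nc2c1ncn2[C@H]1CO[C@@H](CO)O1`: > 100000 nM
- Compound 2 `CCCCCCCC(=O)Nc1nc(N)nc2c1ncn2[C@H]1CO[C@@H](CO)O1`: > 100000 nM
- Compound 3 `CCCCCCCCCCCC(=O)Nc1nc(N)nc2c1ncn2[C@H]1CO[C@@H](CO)O1`: > 100000 nM

In a functional assay on HepG2 cells (Homo sapiens) for cytotoxicity (a higher number here means that more compound is tolerated, a lower number that less compound is tolerated), compound 1 gives > 100000 nM, which is a limit and not a number. Compounds 2 and 3 are limits as well, so the series offers (the limit of > 100000 nM in this assay, at which 3 of the 3 values shown sit).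

Compound 4 `CCCCCCCCCCCCCC(=O)Nc1nc(N)nc2c1ncn2[C@H]1CO[C@@H](CO)O1` has not been measured. It differs from compound 1 as follows: decyl in place of hydrogen on a saturated chain carbon, three bonds along the chain from a carbonyl carbon.

For the measured compounds named here, three measured steps bear on this change: a step that the two limits leave unreadable from compound 1 to compound 2, a step that the two limits leave unreadable from compound 1 to compound 3 and a step that the two limits leave unreadable from compound 2 to compound 3. Their sizes cannot be read, but none ends in a measured number. Compound 3 still gives > 100000 nM, again a limit. No clear step is therefore expected in this assay, in either direction.

The expected step is a number no higher from compound 1 to compound 4 (the limit leaves the size open). For compound 4 the estimated value is 100000 nM, with an expected range of 50000 nM to 200000 nM.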

Compound 4, half-maximal cytotoxic concentration: 56000 nM
Beside the measured number, compound 4's estimate is 1.8-fold (0.25 log units) above it, within the range that was stated.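

For the compounds shown here, compound 4, with the decyl in place of hydrogen, is the first of these amides to give a number rather than a limit in this assay, at 56000 nM. This shows up as an at least 1.7-fold lower number from compound 1 to compound 4 (0.25 log units; that floor lies within the scatter), as an at least 1.7-fold lower number from compound 2 to compound 4 (0.25 log units; that floor lies within the scatter) and as an at least 1.7-fold lower number from compound 3 to compound 4 (0.25 log units; that floor lies within the scatter), and each of these is only a floor, so the true steps may be larger or may not exceed the usual scatter. The steps among compound 1, compound 2 and compound 3 cannot be read, since all three are limits: the limit of > 100000 nM in this assay, at which 3 of the 4 values shown sit.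

The compounds shown leave open how large the true steps to compound 4 are. They also leave open how the number would respond to a still longer chain, or to a chain carrying an amine or a carboxylic acid.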